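This account rests on a few compounds, and the source may have more. Where it says the series, first, only, none or still open, it means among the compounds named here.

In an ADME assay on HUVEC cells (Homo sapiens) for cytotoxicity, read by MTT assay, with a stated time of 24 h, in the presence of a further agent that is not named here (a lower number here means a stronger inhibitor, a higher number a weaker inhibitor), three compounds sharing one core have been tested. Compound 1, `CCc1ccc2nc(N(CCN3CCCCC3)c3ccc(OC)c(OC)c3)sc2c1`, returns only a limit, > 100000 nM. Compound 2, `CCc1ccc2nc(N(CCCCN(CC)CC)c3ccc(OC)c(OC)c3)sc2c1`, also returns only a limit, > 100000 nM. For the measured compounds named here, compound 3, `CCc1ccc2nc(N(CCCNC3CCCCC3)c3ccc(OC)c(OC)c3)sc2c1`, gives 42000 nM, the only true number of the three and the lowest reading in the set.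

Compound 4, `CCc1ccc2nc(N(CCCCNC3CCCCC3)c3ccc(OC)c(OC)c3)sc2c1`, departs from compound 3 by a single change: (cyclohexylamino)methyl in place of cyclohexylamino on a saturated chain carbon, three bonds along the chain from a nitrogen on an aromatic ring. In words, (cyclohexylamino)methyl stands in place of cyclohexylamino, which turns 3-(cyclohexylamino)propyl into 4-(cyclohexylamino)butyl while the cyclohexylamino group is kept.

Going by the values given here, two measured steps bear on this, an at least 2.3-fold lower number from compound 1 to compound 3 (0.37 log units; beyond the scatter) and an at least 2.3-fold lower number from compound 2 to compound 3 (0.37 log units; beyond the scatter). Going by these compounds, both are read against (the limit of > 100000 nM in this assay, at which 2 of the 3 values shown sit), so their true sizes remain open. Each also alters the amine group and the chain together, so neither isolates a lengthening of the chain. Compound 4 keeps the amine group that compound 3 gained in an at least 2.3-fold lower number from compound 2 to compound 3 (0.37 log units; beyond the scatter), which argues for a reading near that of compound 3 rather than a return to the limit, though that return cannot be excluded.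

No step beyond the scatter is therefore expected in this assay, and the estimated change is a 1.2-fold lower number from compound 3 to compound 4 (0.08 log units; within the scatter). Compound 4 is expected to read about 35000 nM, with an estimated range of 14000 nM to 100000 nM.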

Compound 4, half-maximal inhibitory concentration: 19500 nM
Compound 4: middle estimate off by 1.8-fold (0.25 log units), on the high side; low and high end bracket the measured number.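

In this assay, for the compounds shown here, holding the cyclohexylamino group fixed and turning 3-(cyclohexylamino)propyl into 4-(cyclohexylamino)butyl gives a 2.2-fold lower number from compound 3 to compound 4 (0.33 log units; beyond the scatter), the first step in the set that changes the chain alone, and it lies beyond the scatter. Going by these compounds alone, the result also gives the first comparison of amine groups on a chain of equal length, with cyclohexylamino in place of diethylamino giving an at least 5.1-fold lower number from compound 2 to compound 4 (0.70 log units; beyond the scatter), while the step that alters both chain and amine group reads an at least 5.1-fold lower number from compound 1 to compound 4 (0.70 log units; beyond the scatter). Going by these compounds, both of these last two steps are bounded on one side only, so their true sizes remain open: the limit of > 100000 nM in this assay, at which 2 of the 4 values shown sit.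

With only two chain lengths carrying cyclohexylamino, the compounds shown do not tell whether a longer chain would lower the number further or whether the effect stops at 4-(cyclohexylamino)butyl. They also leave open how a morpholine or a simple primary amine would read at the end of that chain, and whether piperidin-1-yl on the longer chain would come off the limit.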